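The source may report more compounds than this note shows. Statements on the series, on what has been measured and on what is new or still open speak of the compounds shown alone.

In an ADME assay on Akata cells (Homo sapiens) for cytotoxicity, with a stated time of 7 days (on this read-out lower numbers stand for higher toxicity in this test and higher numbers for lower toxicity in this test), compound 1 `Nc1nc(NC2CCCCC2)c2ncn(/C=C3/CC3(CO)CO)c2n1` gives > 24000 nM, which is a limit of the test rather than a number. Compound 2 `CCCCCCSc1nc(N)nc2c1ncn2/C=C1/CC1(CO)CO` gives > 20000 nM, also a limit. Compound 3 `CCCCCCCCSc1nc(N)nc2c1ncn2/C=C1/CC1(CO)CO` gives > 20000 nM, again a limit, so compound 3 stands at a limit together with every other value shown, and none stands apart. The move to compound 4 `CNc1nc(N)nc2c1ncn2/C=C1/CC1(CO)CO` is methylamino in place of octylsulfanyl on an aromatic carbon. The measured steps a step that the two limits leave unreadable from compound 1 to compound 3 and a step that the two limits leave unreadable from compound 2 to compound 3 both swapped the group on an aromatic carbon and both came out unreadable, as did a step that the two limits leave unreadable from compound 1 to compound 2. Nothing shown therefore points in either direction, and the expectation in this assay is no step beyond the scatter, most likely another limit. Compound 4 is expected to give 25000 nM, between 10000 nM and 60000 nM, an expected step that the limit leaves unreadable from compound 3 to compound 4.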

Compound 4, half-maximal cytotoxic concentration: > 24000 nM
Compound 4: only a limit was reported; the forecaster's own chance of this, stated with the estimate: 85%; the middle value does not contradict the limit.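

Among these compounds, compound 4, like compound 1, compound 2 and compound 3, reads only as a limit, so no step among them can be read. The compounds shown leave open whether any of these groups on the shared core reaches a measurable cytotoxic concentration in this assay at all.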